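Capping the ring amine of compound 1

This account rests on a few compounds, and the source may have more. Where it says the series, first, only, none or still open, it means among the compounds named here.

Values in a functional assay on HCT-116 cells (Homo sapiens) for cytotoxicity (a higher number here means a weaker inhibitor, a lower number a stronger inhibitor), for the two measured compounds
Compound 1 (`COc1cc(N2CCNCC2)ccc1Nc1nc(NC2CCCCC2)c2nc[nH]c2n1`) – 88 nM
Compound 2 (`COc1cc(N2CCN(C(=O)C3CCC(O)CC3)CC2)ccc1Nc1nc(NC2CCCCC2)c2nc[nH]c2n1`) – 15 nM

Of these two numbers, compound 1 holds the highest at 88 nM and so is the weaker inhibitor of the pair. Compound 3 (`COc1cc(N2CCN(C(=O)N3CCN(C)CC3)CC2)ccc1Nc1nc(NC2CCCCC2)c2nc[nH]c2n1`) has not yet been measured. The change from compound 1 ((4-methylpiperazin-1-yl)carbonyl in place of hydrogen on an amine nitrogen in a ring) puts (4-methylpiperazin-1-yl)carbonyl in place of hydrogen on an amine nitrogen in a ring.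

Within the data shown here, one measured step bears on this change: a 5.9-fold lower number from compound 1 to compound 2 (0.77 log units; beyond the scatter) with (4-hydroxycyclohexyl)carbonyl on the same nitrogen. It is a modest step, but beyond the scatter. Among the measured compounds shown here, it is also the only such step, and the group entering compound 3 is a different one. A step in the same direction is therefore expected, somewhat smaller and with a wide margin. The estimated change is a 4.0-fold lower number from compound 1 to compound 3 (0.60 log units; beyond the scatter) on this single piece of evidence. Compound 3 is expected at 22 nM with an estimated range from 7 nM to 70 nM once it is tested.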

Compound 3, half-maximal inhibitory concentration: 17 nM
Compound 3: the middle estimate sits 1.3-fold (0.11 log units) above what was measured; the measured number falls inside the stated range.
By their numbers in this assay, from the lowest: compounds 2 and 3 (each within the scatter of the next); then compound 1.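

In this assay, the change seen in a 5.2-fold lower number from compound 1 to compound 3 (0.71 log units; beyond the scatter) shows that lowering the number by substituting this amine nitrogen does not depend on the (4-hydroxycyclohexyl)carbonyl group alone, since a second group with a carbonyl attached at the same nitrogen, (4-methylpiperazin-1-yl)carbonyl, also gives a step beyond the scatter. The comparison of the two capped compounds adds that, with the carbonyl kept in place, exchanging 4-hydroxycyclohexyl for 4-methylpiperazin-1-yl makes no difference that can be resolved: a 1.1-fold higher number from compound 2 to compound 3 (0.05 log units; within the scatter), so the two groups cannot be told apart in this assay. No measurement is available that explains why either group lowers the number.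

Both groups attach through a carbonyl, so the compounds shown leave open whether the carbonyl itself is needed, a question that a plain methyl or benzyl group on the same nitrogen would address. Going by these compounds, it also remains open how far the outer part of the group can vary, for instance whether a carboxylic acid or a longer chain in place of the outer ring would keep the number as low.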